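The source may hold more compounds than are shown below. What is called first, only, known or untested is meant among the compounds shown, and "the series" means these compounds.

Three compounds share one core: compound 1 `COc1ccc(C(=O)/C=C/c2cc(-c3cc(OC)c(OC)c(OC)c3)n3nc(-c4ccccc4)cc3n2)cc1`, compound 2 `COc1cc(-c2cc(C(=O)/C=C/c3ccc(Cl)cc3)nc3cc(-c4ccccc4)nn23)cc(OC)c1OC` and compound 3 `COc1ccc(/C=C/C(=O)c2cc(-c3cc(OC)c(OC)c(OC)c3)n3nc(-c4ccccc4)cc3n2)cc1`. In a functional assay on DU-145 cells (Homo sapiens) for antiproliferative activity, read by MTT assay, with a stated time of 24 h (a lower number here means a stronger inhibitor, a higher number a weaker inhibitor), compound 1 gives 25200 nM, compound 2 gives 19500 nM and compound 3 gives 16900 nM. Compound 3 thus holds the lowest of the three numbers, yet the gaps are small: a 1.2-fold lower number from compound 2 to compound 3 (0.06 log units; within the scatter) and a 1.5-fold lower number from compound 1 to compound 3 (0.17 log units; within the scatter). Compound 4 `COc1cc(/C=C/C(=O)c2cc(-c3cc(OC)c(OC)c(OC)c3)n3nc(-c4ccccc4)cc3n2)cc(OC)c1OC` is unmeasured; its change from compound 3 is 3,4,5-trimethoxyphenyl in place of 4-methoxyphenyl on a double-bonded chain carbon bound to a double-bonded chain carbon. Among the measured compounds shown here, the only measured step at that same place, a 1.2-fold lower number from compound 2 to compound 3 (0.06 log units; within the scatter), stayed within the scatter, and no measured step swaps a methoxy-bearing ring for a trimethoxy one. So no step beyond the scatter is expected, a 1.1-fold lower number from compound 3 to compound 4 (0.05 log units; within the scatter). Compound 4 is therefore estimated at 15000 nM, with a range from 6000 nM to 40000 nM.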

Compound 4, half-maximal inhibitory concentration: 17900 nM
The estimate for compound 4 lay 1.2-fold (0.08 log units) below the measured number; measured number inside the range.
By their numbers in this assay, from the lowest: compounds 3, 4, 2 and 1 (each within the scatter of the next).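

At the double-bonded chain carbon, three differently substituted phenyl rings now stay within the scatter of one another: 3,4,5-trimethoxyphenyl in place of 4-methoxyphenyl gives a 1.1-fold higher number from compound 3 to compound 4 (0.02 log units; within the scatter) and, in place of 4-chlorophenyl, gives a 1.1-fold lower number from compound 2 to compound 4 (0.04 log units; within the scatter). Even the ring with three hydrogen-bond acceptors instead of one brings no readable difference here. Nothing available explains this result. On these data alone, every ring at this place is a substituted phenyl, so whether an amine or a carboxylic acid there would give a step beyond the scatter remains open.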